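Adding one methoxy group to compound 2

This account rests on a few compounds, and the source may have more. Where it says the series, first, only, none or still open, it means among the compounds named here.

Measured so far in a functional assay on LoVo cells (Homo sapiens) for inhibition, read by colorimetric assay and MTT assay, with a stated time of 72 h; a higher number here means a weaker inhibitor, a lower number a stronger inhibitor
Compound 1 `COc1ccccc1-c1cnc(OC)n1C` gives 73000 nM
Compound 2 `C=CCCCCOc1ncc(-c2ccccc2OC)n1C` gives 4000 nM

Compound 2 stands lowest of the two at 4000 nM while compound 1 lies well above it. Compound 3 `C=CCCCCOc1ncc(-c2cccc(OC)c2OC)n1C` has not yet been measured. It differs from compound 2 by methoxy in place of hydrogen on an aromatic carbon with methoxy in place of hydrogen on an aromatic carbon, ortho to a methoxy group. For the measured compounds named here, the only measured step is an 18-fold lower number from compound 1 to compound 2 (1.26 log units; beyond the scatter) and it is large. That step came from pent-4-en-1-yl in place of hydrogen on a saturated chain carbon bound to an oxygen on an aromatic ring, a change at a different place from the new methoxy. Going by the values given here, it therefore bears only loosely, and no measured step covers a methoxy addition. No step beyond the scatter is expected in this assay and no firm direction can be given. The estimated 1.1-fold lower number from compound 2 to compound 3 (0.06 log units; within the scatter) is accordingly expected to be small. Compound 3 is expected at 3500 nM with an estimated range from 1200 nM to 10000 nM in this measurement.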

Compound 3, half-maximal inhibitory concentration: 11000 nM
Compound 3: middle estimate off by 3.1-fold (0.50 log units), on the low side; the measured number lies above the stated range.
By their numbers in this assay, from the lowest: compound 2; then compound 3; then compound 1.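

In this assay the aromatic ring that carries the methoxy group proves not to be indifferent to substitution: a further methoxy, ortho to a methoxy group and meta to a large group, brings a 2.8-fold higher number from compound 2 to compound 3 (0.44 log units; beyond the scatter) and so weakens inhibition modestly, though beyond the scatter. For the compounds shown here, this is the first measured change on that ring, and its direction is opposite to an 18-fold lower number from compound 1 to compound 2 (1.26 log units; beyond the scatter) at the chain on the oxygen, so the two places do not respond alike. Nothing available accounts for the weaker inhibition seen with this added methoxy.

As far as these compounds go, whether a hydroxyl, a fluorine or an amine at this same place would shift the number in the same direction stays open. Also open, from the compounds shown here alone, is whether a longer chain in place of pent-4-en-1-yl would go further than compound 2 does.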